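Propyl to cyclohexyl at the aryl-bearing position of the core

The compounds below may be only part of what the source reports. "The series", "measured", "known", "first", "only" and "open" are said of these compounds alone.

Three compounds of the shared core carry a hydrazinyl-urea arm and differ only in the group on the aromatic carbon of the bicyclic core. Compound 1 `Cc1nn(C)c2nc(NNC(=O)Nc3cc(Cl)nc(Cl)c3)cc(-c3ccc(F)cc3)c12` bears 4-fluorophenyl there and gives 25200 nM in a functional assay on HCT-116 cells (Homo sapiens) for cytotoxicity, read by MTT assay, with a stated time of 48 h, in the presence of a further agent that is not named here; on this read-out lower numbers stand for an effect already at smaller amounts and higher numbers for an effect only at larger amounts of compound. Compound 2 `Cc1nn(C)c2nc(NNC(=O)Nc3cc(Cl)nc(Cl)c3)cc(-c3ccco3)c12` carries furan-2-yl and gives 69200 nM in this assay. Compound 3 `CCCc1cc(NNC(=O)Nc2cc(Cl)nc(Cl)c2)nc2c1c(C)nn2C` carries propyl and gives 72200 nM in this assay; this is the highest of the three numbers, though the step of a 1.0-fold higher number from compound 2 to compound 3 (0.02 log units; within the scatter) is within the scatter, while the step of a 2.9-fold higher number from compound 1 to compound 3 (0.46 log units; beyond the scatter) stands beyond it, as does a 2.7-fold higher number from compound 1 to compound 2 (0.44 log units; beyond the scatter).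

Compound 4 `Cc1nn(C)c2nc(NNC(=O)Nc3cc(Cl)nc(Cl)c3)cc(C3CCCCC3)c12` is not yet measured. It differs from compound 3 by cyclohexyl in place of propyl on an aromatic carbon.

Within the data shown here, no measured step involves cyclohexyl. Among the measured compounds shown here, the steps that bear on the position show that 4-fluorophenyl gives a lower number than either furan-2-yl or propyl, and that furan-2-yl and propyl are indistinguishable. A six-membered non-aromatic ring of carbon only does not match either case exactly, so the expectation is that compound 4 sits near compound 3, with an estimated step of a 1.3-fold lower number from compound 3 to compound 4 (0.12 log units; within the scatter) that should not exceed the scatter by much. In this assay compound 4 is therefore expected to give about 55000 nM, within a range of 20000 nM to 150000 nM.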

Compound 4, half-maximal effective concentration: 38000 nM
Compound 4: the middle estimate sits 1.4-fold (0.16 log units) above what was measured, and the stated range covers the measured number.
By their numbers in this assay, from the lowest: compounds 1, 4, 2 and 3 (each within the scatter of the next, the first and the last beyond it).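

Cyclohexyl cannot be separated from any of the other three groups at this position in this assay: the steps of a 1.9-fold lower number from compound 3 to compound 4 (0.28 log units; within the scatter) and a 1.8-fold lower number from compound 2 to compound 4 (0.26 log units; within the scatter) and a 1.5-fold higher number from compound 1 to compound 4 (0.18 log units; within the scatter) all lie within the scatter. The earlier compounds divided the position into two sets, with 4-fluorophenyl on one side and furan-2-yl and propyl on the other, whereas compound 4, with its six-membered non-aromatic ring of carbon only, belongs clearly to neither set, so that division no longer accounts for every group seen here. No measurement at hand bears on the reason for these numbers.

A longer chain such as hexyl, or a plain phenyl, would test whether any carbon-only group at this position can be separated from cyclohexyl, and an amine or a carboxylic acid would test whether a group of another kind moves the number beyond the scatter. How these groups rank without the further agent present in this read-out also remains open, as the compounds shown give only this one setting.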